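The compounds below may be only part of what the source reports. "The series", "measured", "known", "first", "only" and "open" are said of these compounds alone.

Measured in a functional assay on the whole organism (Tail, strain ICR) with Mus musculus as the target, in the tail flick test, with a stated time of 90 min, at a dose of 25 umol/kg by the oral route; on this read-out lower numbers stand for a weaker effect and higher numbers for a stronger effect at the one dose given:
compound 1 `O=C(CN(c1ncnc2c1ncn2C1CCCCO1)C1CC1)N[C@@H](CO)C(=O)OCc1ccccc1`, 32.2%
compound 2 `C[C@@H](O)[C@H](NC(=O)CN(c1nc(Cl)nc2[nH]cnc12)C1CC1)C(=O)O`, 35.9%
compound 3 `CC[C@H](C)[C@H](NC(=O)CN(c1ncnc2c1ncn2C1CCCCO1)C1CC1)C(=O)OCc1ccccc1`, 22.6%

Compound 3 has the lowest of the three numbers. Its nearest neighbour is compound 1, which lies higher by a margin within the scatter, so the two cannot be ordered; compound 2 lies further above it, beyond the scatter.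

Compound 4 `O=C(CN(c1ncnc2c1ncn2C1CCCCO1)C1CC1)NCC(=O)OCc1ccccc1` is not yet measured. It differs from compound 3 in one place: hydrogen in place of sec-butyl on a saturated chain carbon bound to an amide-type nitrogen and a carbonyl carbon.

Among the compounds with values here, the only measured step at this position is a number 9.6 percentage points lower from compound 1 to compound 3 (within the scatter), which exchanged one side chain for another on the same carbon. Within the data shown here, no measured pair shows the removal of a side chain at this carbon. The new change is therefore untested in kind. Among the measured compounds shown here, the single step at this place did not move the read-out beyond the scatter, and nothing in the three numbers points in a direction. The expected step of a number 4.4 percentage points higher from compound 3 to compound 4 (within the scatter) in this assay is therefore estimated as none beyond the scatter. For compound 4 the expected value in this assay is 27%, with a range from 12% to 42%.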

Compound 4, a percentage reported as activity, at one dose (the size of the read-out at that dose, not a potency): 25.9%
For compound 4 the middle estimate is 1.1 percentage points above the measured one, and the stated range covers the measured number.
By their numbers in this assay, from the lowest: compounds 3, 4, 1 and 2 (each within the scatter of the next, the first and the last beyond it).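

In this assay, removing the side chain at this saturated chain carbon bound to an amide-type nitrogen and a carbonyl carbon gives a number 3.3 percentage points higher from compound 3 to compound 4 (within the scatter), and the same hydrogen in place of hydroxymethyl gives a number 6.3 percentage points lower from compound 1 to compound 4 (within the scatter). With hydrogen now added to sec-butyl and hydroxymethyl, the read-out at this one dose does not separate the three groups, so the presence of a side chain at this carbon shows no effect beyond the scatter in this set. No measurement of any other kind bears on this result.

From the compounds shown here alone, whether a side chain ending in a primary amine, or one carrying a phenyl ring, would move the read-out beyond the scatter remains open. Compound 2 differs from these compounds in more than one place, so its value cannot be assigned to this position.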